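A few compounds are considered here, and "the series" means these few. Any claim that something is new, unique, unknown or untested is made for them only; others in the source may bear on it.

Compound 1 `Cc1ncnc2c1c(-c1cccs1)cn2[C@@H]1O[C@H](CO)[C@@H](O)[C@H]1O`: in a functional assay on CEM-DNR-bulk cells (Homo sapiens), read by MTT assay, with a stated time of 72 h (a higher number here means a weaker inhibitor, a lower number a stronger inhibitor), compound 1 gives > 20000 nM, which is a limit of the assay and not a number.
Compound 2 `COc1ncnc2c1c(-c1ccsc1)cn2[C@@H]1O[C@H](CO)[C@@H](O)[C@H]1O`: in this assay compound 2 gives 7640 nM.
Compound 3 `Cc1ncnc2c1c(-c1cc3ccccc3o1)cn2[C@@H]1O[C@H](CO)[C@@H](O)[C@H]1O`: in this assay compound 3 gives > 20000 nM, again a limit of the assay.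

Compound 3 thus stands at the limit of > 20000 nM in this assay, at which 2 of the 3 values shown sit, with only a limit known for it. The step that the two limits leave unreadable from compound 1 to compound 3 cannot be read, since both of its ends sit at the limit of > 20000 nM in this assay, at which 2 of the 3 values shown sit. Compound 4 `Cc1ncnc2c1c(-c1ccsc1)cn2[C@@H]1O[C@H](CO)[C@@H](O)[C@H]1O` differs from compound 3 by thiophen-3-yl in place of 1-benzofuran-2-yl on an aromatic carbon. Among the measured compounds shown here, no measured step bears directly on this change. Compound 2 also carries thiophen-3-yl, though it differs from compound 4 in another place. In this assay compound 2 gives 7640 nM. Compound 4 is therefore expected near the limit, at 15000 nM, within 5000 nM to 40000 nM. That estimate means an expected step of an at least 1.3-fold lower number from compound 3 to compound 4 (0.12 log units; that floor lies within the scatter).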

Compound 4, half-maximal inhibitory concentration: 8560 nM
Estimate against measurement, compound 4: 1.8-fold (0.24 log units) above; the range from low to high includes it.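

Putting thiophen-3-yl at this position gives a readable value in this assay, with an at least 2.3-fold lower number from compound 3 to compound 4 (0.36 log units; beyond the scatter) and an at least 2.3-fold lower number from compound 1 to compound 4 (0.36 log units; beyond the scatter). Compound 1 and compound 3 are known only as limits of the assay, so these two steps are floors: the limit of > 20000 nM in this assay, at which 2 of the 4 values shown sit.
Methyl in place of methoxy on the aromatic carbon, with thiophen-3-yl kept, gives a 1.1-fold higher number from compound 2 to compound 4 (0.05 log units; within the scatter), so that exchange cannot be told apart from scatter. Going by these compounds, the true size of the two floor steps stays open. So does the effect of an amine in place of methyl or methoxy on the shared core.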